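Replacing a Chlorinated Side Chain by a Fluorinated Alkene

A few compounds are considered here, and "the series" means these few. Any claim that something is new, unique, unknown or untested is made for them only; others in the source may bear on it.

Measured compounds:
compound 1, `O=S(=O)(CCC(F)(Cl)C(F)(F)Cl)c1nc2ccccc2s1`, 4500 nM
compound 2, `O=S(=O)(CCC(F)(Cl)C(F)(F)Cl)c1nc2ccc(Cl)cc2s1`, 6000 nM

For the measured compounds named here, in a functional assay on SH-SY5Y cells (Homo sapiens) for cytotoxicity, read by MTT assay, with a stated time of 48 h (a lower number here means a stronger inhibitor, a higher number a weaker inhibitor), compound 1 gives 4500 nM, the lower of the two numbers measured so far; its nearest neighbour is compound 2, which gives 6000 nM. Going by the values given here, the only measured step, a 1.3-fold higher number from compound 1 to compound 2 (0.12 log units; within the scatter), lies within the scatter, so the two compounds cannot be ordered. Compound 3, `O=S(=O)(CCC(F)=C(F)F)c1nc2ccccc2s1`, is not yet measured; it differs from compound 1 by 1,2,2-trifluoroethenyl in place of 1,2-dichloro-1,2,2-trifluoroethyl on a saturated chain carbon, two bonds along the chain from a sulfonyl sulfur. Among the compounds with values here, no measured step touches this part of the chain, so the step from compound 1 to compound 2 bears on it only indirectly, by showing how little one change elsewhere on the shared core moved the number. Within the data shown here, with no direct precedent, the expected step is a 1.1-fold higher number from compound 1 to compound 3 (0.05 log units; within the scatter), that is, none beyond the scatter in either direction. Compound 3 is therefore estimated at 5000 nM in this assay, within a range from 1800 nM to 14000 nM.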

Compound 3, half-maximal inhibitory concentration: 2640 nM
Compound 3: middle estimate off by 1.9-fold (0.28 log units), on the high side; the range from low to high includes it.
By their numbers in this assay, from the lowest: compounds 3, 1 and 2 (each within the scatter of the next, the first and the last beyond it).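

For the compounds shown here, compound 3 gives the only reading on this part of the chain: with 1,2,2-trifluoroethenyl in place of 1,2-dichloro-1,2,2-trifluoroethyl, this assay shows a 1.7-fold lower number from compound 1 to compound 3 (0.23 log units; within the scatter) and so no difference that can be told from repeat scatter. The two chlorine atoms can therefore leave, and a double bond outside aromatic rings can enter, on a saturated chain carbon, two bonds along the chain from a sulfonyl sulfur, without a step beyond the scatter. Nothing among the data shown offers a reason for this result.

From the compounds shown here alone, it remains open how an amine, a carboxylic acid or a longer chain would read at this place. Also open, going by these compounds, is whether the 1,2,2-trifluoroethenyl group and the aromatic chloro of compound 2, taken together on one core, would stay within the scatter of compound 3.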